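This account rests on a few compounds, and the source may have more. Where it says the series, first, only, none or still open, it means among the compounds named here.

Measured compounds:
compound 1 `COc1ccc(Nc2cncc(N3CC4CC(C3)N4)c2)cc1` gives 0.0598 nM
compound 2 `Clc1ccc(Nc2ccc(N3CC4CC(C3)N4)cn2)cc1` gives 2.49 nM
compound 3 `c1ccc(Nc2ccc(N3CC4CC(C3)N4)nn2)cc1` gives 441 nM

These three compounds were measured in an assay on cell membranes for displacement of a labelled ligand from Neuronal acetylcholine receptor; alpha4/beta2 (Rattus norvegicus); a lower number here means a stronger inhibitor, a higher number a weaker inhibitor. Among the three numbers, compound 2 stands in the middle: its number is higher than that of compound 1 and lower than that of compound 3, and both gaps lie beyond the scatter of this assay. Compound 1 thus has the lowest number of the three and compound 3 the highest.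

Compound 4 `Cc1ccc(Nc2ccc(N3CC4CC(C3)N4)cn2)cc1` has not been measured in this assay. It differs from compound 2 in one place: methyl in place of chloro on an aromatic carbon. The two compounds otherwise share the same core and the same pattern of attachment.

Going by the values given here, no step between two measured compounds that differ only in this place is available, so the size of the step from compound 2 to compound 4 cannot be read from the measured compounds themselves. Given that the change is confined to a single atom exchanged at the same place, a step within the scatter, or only slightly beyond it toward a higher number, is expected: the expected step is a 1.4-fold higher number from compound 2 to compound 4 (0.15 log units; within the scatter).

Compound 4 is therefore estimated at 3.5 nM in this assay, with a range from 1 nM to 12 nM.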

Compound 4, inhibition constant: 52.1 nM
For compound 4 the middle estimate is 15-fold (1.17 log units) below the measured one; measured number outside the range, above it.
By their numbers in this assay, from the lowest: compound 1; then compound 2; then compound 4; then compound 3.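

In this assay, the change from 4-chlorophenyl to 4-methylphenyl gives a 21-fold higher number from compound 2 to compound 4 (1.32 log units; beyond the scatter) and is a large step, so this place on the aromatic ring, para to a large group, clearly matters for the number in this assay. The pair is the first among these compounds to differ in one place only, whereas the earlier compounds differed from one another in more than one place and could not isolate any single change. The exchange is one heavy atom for one heavy atom, with no ring, hydrogen-bond donor, hydrogen-bond acceptor or net charge entering or leaving, so none of these counts separates the two groups, and nothing available explains why the step is this large.

The compounds shown hold only chloro and methyl at this place on this core, so where fluoro, a nitrile or an amine would fall relative to them remains open. Going by these compounds, it also remains open whether the same exchange would produce a step of similar size on the core of compound 1 or the core of compound 3.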